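Nitrogen substituent swap in a cytotoxicity series

The source may report more compounds than this note shows. Statements on the series, on what has been measured and on what is new or still open speak of the compounds shown alone.

Compound 1 `COc1cc2c(=O)c(C(=O)c3ccc(C)cc3)cn(CC3CC3)c2cc1OC` has no number in an ADME assay on Huh-7 cells (Homo sapiens) for cytotoxicity; on this read-out higher numbers stand for weaker inhibition of growth and lower numbers for stronger inhibition of growth: compound 1 is recorded as "not active" (no number reported). Compound 2 `CN1CCN(c2cc3c(cc2F)c(=O)c(NC(=O)NCc2ccc(Cl)cc2)cn3Cc2ccc(Cl)cc2)CC1` is likewise recorded as "not active" (no number reported) in this assay. Compound 3 `O=C(OCc1ccc(Cl)cc1)c1cn(Cc2ccc(Cl)cc2)c2cc(N3CCNCC3)c(F)cc2c1=O`, built on a different substitution pattern, gives 1100 nM in this assay. Compound 4 `COc1cc2c(=O)c(C(=O)c3ccc(C)cc3)cn(Cc3ccc(Cl)c(Cl)c3)c2cc1OC` differs from compound 1 by 3,4-dichlorophenyl in place of cyclopropyl on a saturated chain carbon bound to an aromatic nitrogen. Among the compounds with values here, no measured pair shows the effect of this change, so nothing beyond the scatter can be claimed for the step in this assay in either direction. Given that compound 1 gives "not active" (no number reported), compound 4 is expected to show weak growth inhibition as well. Compound 4 is estimated at 20000 nM in this assay, with a range from 5000 nM to 100000 nM, and a strong chance that again no number is reported.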

Compound 4, concentration for 50% growth inhibition: "not active" (no number reported)
Compound 4: no number reported; the estimate stays without a comparison.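

Compound 1 and compound 4 both lack a number in this assay, and no step can be read between them. The compounds shown leave open how far the swap from cyclopropylmethyl to 3,4-dichlorobenzyl shifts growth inhibition. No further evidence bears on this result.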